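This account rests on a few compounds, and the source may have more. Where it says the series, first, only, none or still open, it means among the compounds named here.

Working notes on the series. Compound 1 `COc1cc(C(=O)O)ccc1OCCCCOc1ccc(C(=O)C(C)C)c(O)c1C` carries an acid on one aryl end; in an assay on HEK293 cells for positive allosteric modulation of metabotropic glutamate receptor 2 (Rattus norvegicus), read by thallium flux, with a stated time of 2.5 min (on this read-out higher numbers stand for an effect only at larger amounts of compound and lower numbers for an effect already at smaller amounts), compound 1 gives 113 nM. Among the measured compounds shown here, compound 2 `COC(=O)c1ccc(OCCCCOc2ccc(C(=O)CC3CCCC3)c(O)c2C)cc1` replaces that acid with a methyl ester and lengthens the ketone side chain; in this assay compound 2 gives "not determined" (no result reported), so compound 2 stands at no number at all, and no step between measured compounds can be sized from it. Compound 3 `Cc1c(OCCCCOc2ccc(C(=O)O)cc2F)ccc(C(=O)CC2CCCC2)c1O` is reached from compound 2 by 4-carboxy-2-fluorophenyl in place of 4-(methoxycarbonyl)phenyl on an oxygen on a saturated carbon. For the measured compounds named here, the direction of this step in this assay cannot be read from compound 2; what the series offers is only that the acid-bearing compound 1 sits at 113 nM. Compound 3 is therefore expected near that mark, estimated at 150 nM with a likely range from 40 nM to 600 nM, because compound 1 gives 113 nM in the same read-out and compound 3 again carries the acid.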

Compound 3, half-maximal effective concentration: 639 nM
Estimate against measurement, compound 3: 4.3-fold (0.63 log units) below, and the stated range ends below it.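

Among the compounds shown here, compound 2 has no single number in this assay, and no step to compound 3 can be read from it. The compounds shown leave open what the change from 4-(methoxycarbonyl)phenyl to 4-carboxy-2-fluorophenyl alone does to this read-out. No evidence at hand bears on the result for compound 3.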